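Cyano for methyl on the aryl ether of a sultam

The source may hold more compounds than are shown below. What is called first, only, known or untested is meant among the compounds shown, and "the series" means these compounds.

Of the compounds shown here, two of a shared core have been measured in a functional assay on Flp-In T-REx293 cells for antagonist activity at Free fatty acid receptor 1 (Homo sapiens), read by calcium flux; a lower number here means a stronger inhibitor, a higher number a weaker inhibitor. Compound 1, `O=S1(=O)c2ccccc2CN1c1cc(F)cc(Oc2cccnc2)c1`, carries a pyridin-3-yl on the ether oxygen; compound 2, `Cc1ccc(Oc2cc(F)cc(N3Cc4ccccc4S3(=O)=O)c2)cc1`, carries a 4-methylphenyl there. For compound 1 this assay reports only a limit, > 100000 nM, and no number. Compound 2 gives 2880 nM, the only actual number shown, so its standing rests on that value alone and on the step of an at least 34-fold lower number from compound 1 to compound 2 (1.54 log units; beyond the scatter), which is large and rests on (the limit of > 100000 nM in this assay, at which 1 of the 2 values shown sits).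

Compound 3, `N#Cc1ccc(Oc2cc(F)cc(N3Cc4ccccc4S3(=O)=O)c2)cc1`, differs from compound 2 by cyano in place of methyl on an aromatic carbon. Among the compounds with values here, no measured step concerns a change of this kind; the step from compound 1 to compound 2 exchanges the whole ring on the ether oxygen and so bears on the present step only distantly. A modest step, possibly toward a higher number, is therefore expected in this assay, but nothing shown forces a direction. For compound 3 the expected step is a 1.7-fold higher number from compound 2 to compound 3 (0.24 log units; within the scatter). Compound 3 is estimated at 5000 nM, with a range from 1500 nM to 20000 nM.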

Compound 3, half-maximal inhibitory concentration: 617 nM
Compound 3: the middle estimate sits 8.1-fold (0.91 log units) above what was measured; the measured number lies below the stated range.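

Keeping the ring on the ether oxygen and changing only the group para to a large group, the series moves beyond the scatter in this assay, with a 4.7-fold lower number from compound 2 to compound 3 (0.67 log units; beyond the scatter); the earlier pair had exchanged the whole ring, so this is the first sign that this single position on the ring matters by itself. The step is modest, but it runs toward a stronger inhibitor, and compound 3 now has the lowest number of the three, with an at least 160-fold lower number from compound 1 to compound 3 (2.20 log units; beyond the scatter) as the large step across the whole ring on the ether oxygen. The value for compound 1 is a limit and not a number, so this large step gives only a minimum size: the limit of > 100000 nM in this assay, at which 1 of the 3 values shown sits.

The compounds shown give no cause for the effect of cyano, and a single exchange cannot show whether the trend would continue with a carboxylic acid, an amide or a trifluoromethyl in the same place. On these data alone, it also remains open whether cyano would have any comparable effect on the pyridin-3-yl ring, or whether a second group on the 4-cyanophenyl ring would add to it.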